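The source may hold more compounds than are shown below. What is called first, only, known or untested is meant among the compounds shown, and "the series" means these compounds.

Measured so far:
- compound 1 `O=C(NCc1ccc(F)cc1)c1nc(NCCO)c2cccnc2c1O` at 91000 nM
- compound 2 `C[C@H](CO)Nc1nc(C(=O)NCc2ccc(F)cc2)c(O)c2ncccc12` at 69000 nM

In a toxicity assay on C8166 cells (Homo sapiens) for cytotoxicity, read by MTT assay, with a stated time of 72 h (on this read-out higher numbers stand for lower toxicity in this test and lower numbers for higher toxicity in this test), compound 2 gives 69000 nM, which stands within the scatter of compound 1 and leaves no order between the two. Compound 3 `O=CNCCCCCCNc1nc(C(=O)NCc2ccc(F)cc2)c(O)c2ncccc12` has not yet been measured. It carries 6-(formylamino)hexyl in place of 1-(hydroxymethyl)ethyl on a nitrogen on an aromatic ring. Among the compounds with values here, only one measured step bears on this place: a 1.3-fold lower number from compound 1 to compound 2 (0.12 log units; within the scatter). That step is small and involves only a methyl, so it sets no size for an exchange of this extent, and the data hold no long chain for comparison. A moderate move towards a lower number is therefore expected, with wide uncertainty. The expected step is a 2.3-fold lower number from compound 2 to compound 3 (0.36 log units; beyond the scatter). For compound 3 the estimated value is 30000 nM, with an expected range of 8000 nM to 100000 nM.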

Compound 3, half-maximal cytotoxic concentration: 199000 nM
Compound 3: the middle estimate sits 6.6-fold (0.82 log units) below what was measured; the measured number lies above the stated range.
By their numbers in this assay, from the lowest: compounds 2 and 1 (each within the scatter of the next); then compound 3.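

In this assay, within the data shown here, 6-(formylamino)hexyl in place of 1-(hydroxymethyl)ethyl on a nitrogen on an aromatic ring gives a 2.9-fold higher number from compound 2 to compound 3 (0.46 log units; beyond the scatter), the first step beyond the scatter, so this position carries a larger chain with no rise in toxicity in this test. The comparison with the shorter hydroxy-ended chain points the same way: 4-(formylamino)butyl in place of hydroxy on a saturated chain carbon, two bonds along the chain from a nitrogen on an aromatic ring, gives a 2.2-fold higher number from compound 1 to compound 3 (0.34 log units; beyond the scatter). No measurement at hand offers an explanation for this shift.

Compound 3 alters chain length and chain end together, and their shares in the step remain unresolved. A plain hexyl chain or a 6-aminohexyl group would help separate them, and a longer chain would show whether the trend continues.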